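The source may hold more compounds than are shown below. What is called first, only, known or untested is meant among the compounds shown, and "the series" means these compounds.

Measured compounds in an assay on CHO cells with metabotropic glutamate receptor 2 (Homo sapiens) as the target, read by FLIPR; a lower number here means that less compound is needed, a higher number that more compound is needed for the effect:
- compound 1 `CCCn1c(CN2CCN(c3ncc(Cl)cn3)CC2)nc2ccccc21` gives 794 nM
- compound 2 `Cn1c(CN2CCN(c3nc(Cl)ccc3C(F)(F)F)CC2)nc2cc(F)ccc21` gives 200 nM
- compound 3 `FC(F)(F)c1ccc(Cl)nc1N1CCN(Cc2nc3ccccc3n2Cc2ccccc2)CC1` gives 126 nM

Compound 1 stands with the highest number of the three. Compound 2 is nearest to it and compound 3 furthest, and both of those gaps lie beyond the scatter; compound 2 and compound 3 differ from compound 1 in more than one place, so their numbers say nothing about any single change.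

Compound 4 `CCn1c(CN2CCN(c3ncc(Cl)cn3)CC2)nc2ccccc21` has not yet been measured. Against compound 1 the change is hydrogen in place of methyl on a saturated chain carbon, two bonds along the chain from an aromatic nitrogen. The propyl on the aromatic nitrogen of compound 1 becomes an ethyl. Going by the values given here, no measured pair differs only in this chain, so there is no step to lean on; compound 2 carries a methyl and compound 3 a benzyl at that nitrogen, but each also carries a different aryl on the piperazine.

A change of this size, one chain carbon removed, is expected to give a step from compound 1 to compound 4 of a 1.0-fold higher number from compound 1 to compound 4 (0.00 log units; within the scatter) in this assay, with no direction claimed beyond the scatter. The number for compound 4 is estimated at 800 nM, within a range of 300 nM to 2200 nM.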

Compound 4, half-maximal effective concentration: 158 nM
Compound 4: middle estimate off by 5.1-fold (0.70 log units), on the high side; the measured number lies below the stated range.
By their numbers in this assay, from the lowest: compounds 3, 4 and 2 (each within the scatter of the next); then compound 1.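

In this assay, going by these compounds alone, the substituent on the aromatic nitrogen gives the first single-change reading: with the rest of the structure held fixed, propyl to ethyl gives a 5.0-fold lower number from compound 1 to compound 4 (0.70 log units; beyond the scatter). The position is therefore sensitive to the length of this chain, at least on the core of compound 1 and over this one shortening. No such reading comes from compound 2 or compound 3, which carry a methyl and a benzyl at that nitrogen but also a different aryl on the piperazine, and nothing available bears on the reason for the step.

From the compounds shown here alone, a single step between two chain lengths does not establish a trend, so it remains open whether the number keeps moving, levels off or turns back with a butyl, a cyclopropylmethyl or a 2-methoxyethyl at this nitrogen on the same core. Going by these compounds, it also remains open whether propyl to ethyl gives a step of similar size when the piperazine carries the aryl of compound 2 or compound 3, which would need a matched pair on that aryl.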